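This account rests on a few compounds, and the source may have more. Where it says the series, first, only, none or still open, it means among the compounds named here.

Values in a functional assay on LNCaP cells (Homo sapiens) for antiproliferative activity, read by WST assay, with a stated time of 3 days; a higher number here means a weaker inhibitor, a lower number a stronger inhibitor:
- compound 1 `CCCCOc1c(-c2cc(OC)c(OC)c(OC)c2)oc2ccccc2c1=O`: 8900 nM
- compound 2 `CCN(CC)CCCCCOc1c(-c2cc(OC)c(OC)c(OC)c2)oc2ccccc2c1=O`: 10000 nM
- compound 3 `CCCN(CCC)CCCCOc1c(-c2cc(OC)c(OC)c(OC)c2)oc2ccccc2c1=O`: 16800 nM

Compound 3 stands level with the other two within the scatter: a 1.9-fold higher number from compound 1 to compound 3 (0.28 log units; within the scatter), and a 1.7-fold higher number from compound 2 to compound 3 (0.23 log units; within the scatter). Compound 4 `CCCCN(CCCC)CCCCOc1c(-c2cc(OC)c(OC)c(OC)c2)oc2ccccc2c1=O` differs from it by dibutylamino in place of dipropylamino on a saturated chain carbon, four bonds along the chain from an oxygen on an aromatic ring, on a saturated chain carbon, four bonds along the chain from an oxygen on an aromatic ring. The nearest measured change in the amino group is a 1.7-fold higher number from compound 2 to compound 3 (0.23 log units; within the scatter). a 1.1-fold higher number from compound 1 to compound 2 (0.05 log units; within the scatter) also bears on it. Neither left the scatter, so no step beyond the scatter is expected in this assay. The expected step is a 1.1-fold lower number from compound 3 to compound 4 (0.05 log units; within the scatter). For compound 4 the estimated value is 15000 nM, with an expected range of 7000 nM to 30000 nM.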

Compound 4, half-maximal inhibitory concentration: 7800 nM
Compound 4: the middle estimate sits 1.9-fold (0.28 log units) above what was measured; the range from low to high includes it.
By their numbers in this assay, from the lowest: compounds 4, 1, 2 and 3 (each within the scatter of the next, the first and the last beyond it).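

In this assay dibutylamino in place of dipropylamino gives a 2.2-fold lower number from compound 3 to compound 4 (0.33 log units; beyond the scatter) and is the only step among these compounds beyond the scatter, a modest one. The other two steps, a 1.3-fold lower number from compound 2 to compound 4 (0.11 log units; within the scatter) and a 1.1-fold lower number from compound 1 to compound 4 (0.06 log units; within the scatter) both stay within the scatter, so dibutylamino at this place stands level with the hydrogen of compound 1. Nothing at hand accounts for the step from dipropylamino to dibutylamino.

Going by these compounds, whether a ring amine such as piperidine or morpholine, or a carboxylic acid, at this place would give a larger step stays open. So does whether longer chains on the nitrogen, such as dipentylamino, would continue the change seen with dibutylamino.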